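Two weak channel blockers and an untested nitrile analogue

The source may report more compounds than this note shows. Statements on the series, on what has been measured and on what is new or still open speak of the compounds shown alone.

The study measures inhibition in an assay on SH-SY5Y cells for inhibition of Voltage-dependent N-type calcium channel subunit alpha-1B (Homo sapiens), read by FLIPR and calcium flux, with stated times of 600 s and 300 s, in the presence of a further agent that is not named here; on this read-out higher numbers stand for weaker inhibition and lower numbers for stronger inhibition. Compound 1 `CN(C)CCCOc1ccc(CN(C)c2nc3ccc(Oc4ccc(C#N)cc4)cc3s2)cc1` gives 69000 nM in this assay, and compound 2 `CN(C)CCCOc1ccc(CNc2nc3ccc(Oc4cccc(C(F)(F)F)c4)cc3s2)cc1` gives 51000 nM. Compound 2 stands at the lower of the two numbers, with compound 1 close by and within the scatter. Compound 3 `CN(C)CCCOc1ccc(CNc2nc3ccc(Oc4ccc(C#N)cc4)cc3s2)cc1` differs from compound 2 by 4-cyanophenyl in place of 3-(trifluoromethyl)phenyl on an oxygen on an aromatic ring. Going by the values given here, no step between measured compounds is available, so the effect of this change is unknown, though both measured compounds are weak. Compound 3 is expected to show a step of a 1.2-fold higher number from compound 2 to compound 3 (0.07 log units; within the scatter) that lies within the scatter. Compound 3 is estimated at 60000 nM, between 25000 nM and 150000 nM.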

Compound 3, half-maximal inhibitory concentration: 105000 nM
The estimate for compound 3 lay 1.8-fold (0.24 log units) below the measured number; the measured number falls inside the stated range.
By their numbers in this assay, from the lowest: compounds 2, 1 and 3 (each within the scatter of the next, the first and the last beyond it).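

In this assay, 4-cyanophenyl in place of 3-(trifluoromethyl)phenyl on an oxygen on an aromatic ring gives a 2.1-fold higher number from compound 2 to compound 3 (0.31 log units; beyond the scatter), so this position registers a modest change, just beyond the scatter. With 4-cyanophenyl kept, hydrogen in place of methyl on the nitrogen gives a 1.5-fold higher number from compound 1 to compound 3 (0.18 log units; within the scatter), which shows no readable effect at that nitrogen. No evidence is available to explain either step.

The compounds shown do not separate the change of group from the change of its place on the ring. They also leave open how a carboxylic acid or an amine would fare on that ring.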